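Chloro to Methoxy on an Aromatic Carbon

The source may report more compounds than this note shows. Statements on the series, on what has been measured and on what is new or still open speak of the compounds shown alone.

compound 1, `COc1cc(C(=O)c2cn(-c3cc(OC)c(OC)c(OC)c3)cc2-c2ccccc2)cc(OC)c1OC`: > 5000 nM
compound 2, `COc1cc(C(=O)c2cn(-c3ccccc3)cc2-c2ccccc2Cl)cc(OC)c1OC`: 76 nM

Of the compounds shown here, two have been measured in a functional assay on MCF7 cells (Homo sapiens) for cytotoxicity, read by MTT assay, with a stated time of 96 h; on this read-out higher numbers stand for weaker inhibition and lower numbers for stronger inhibition. In this assay compound 1 reaches only the limit of > 5000 nM, which is not a number. Compound 2, in this assay, gives 76 nM, and this is the only number shown. The result for compound 1 is a limit (the limit of > 5000 nM in this assay, at which 1 of the 2 values shown sits). Compound 3, `COc1ccccc1-c1cn(-c2ccccc2)cc1C(=O)c1cc(OC)c(OC)c(OC)c1`, has not yet been measured. It differs from compound 2 in one place: methoxy in place of chloro on an aromatic carbon. No step between measured compounds is shown for this change, so no measured precedent sets its size. The step from compound 2 to compound 3 in this assay is expected to be a modest weakening at most, possibly none beyond the scatter, given as a 2.0-fold higher number from compound 2 to compound 3 (0.30 log units; within the scatter). Compound 3 is therefore estimated at 150 nM, in the range 40 nM to 700 nM.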

Compound 3, half-maximal inhibitory concentration: 190 nM
Compound 3: middle estimate off by 1.3-fold (0.10 log units), on the low side; low and high end bracket the measured number.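

In this assay, among these compounds, methoxy in place of chloro on an aromatic carbon, ortho to a large group, gives the first measured step at this position: a 2.5-fold higher number from compound 2 to compound 3 (0.40 log units; beyond the scatter). The change from 2-chlorophenyl to 2-methoxyphenyl therefore carries a modest but real cost, and compound 3 still gives a measured value of 190 nM rather than a limit. Nothing shown here gives a cause for this step.

The compounds shown leave open whether another group at this position, such as an amine, a hydroxyl or a longer alkoxy chain, would stay close to compound 2 or move further from it. They also leave open what this position adds on the core of compound 1, whose > 5000 nM is a limit and which differs from the others in more than one place.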